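Cyclohexyl carbamate series: cytotoxicity limits and one open compound

This account rests on a few compounds, and the source may have more. Where it says the series, first, only, none or still open, it means among the compounds named here.

Measured in an ADME assay on HEK-293T cells (Homo sapiens) for cytotoxicity, with a stated time of 72 h; a higher number here means that more compound is tolerated, a lower number that less compound is tolerated:
- compound 1 `CC(C)C[C@H](NC(=O)OC1CCC(C)(C)CC1)C(=O)N[C@H](C=O)C[C@@H]1CCNC1=O` reaches the limit, > 100000 nM
- compound 2 `CC(C)C[C@H](NC(=O)OC1CCC(C)(C)CC1)C(=O)N[C@@H](C[C@@H]1CCNC1=O)C(O)S(=O)(=O)O` reaches the limit, > 100000 nM
- compound 3 `CC(C)C[C@H](NC(=O)OC(c1ccccc1)C1CCC(F)(F)CC1)C(=O)N[C@H](C=O)C[C@@H]1CCNC1=O` reaches the limit, > 100000 nM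

Compound 2 differs from compound 1 by hydroxy(sulfo)methyl in place of formyl on a saturated chain carbon bound to an amide-type nitrogen and a saturated chain carbon; the step that the two limits leave unreadable from compound 1 to compound 2 cannot be read, since both ends are limits. Compound 3 carries a different core; the difference between the two cores is not broken down here. Compound 4 `CC(C)C[C@H](NC(=O)OC(c1ccccc1)C1CCC(F)(F)CC1)C(=O)N[C@@H](C[C@@H]1CCNC1=O)C(O)S(=O)(=O)O`, not yet measured, repeats the same change on the core of compound 3: hydroxy(sulfo)methyl in place of formyl on a saturated chain carbon bound to an amide-type nitrogen and a saturated chain carbon.

For compound 4 the expected step that the limit leaves unreadable from compound 3 to compound 4 in this assay rests on (the limit of > 100000 nM in this assay, at which 3 of the 3 values shown sit), which holds for every measured value, including the pair where this change was already made. Compound 4 is therefore estimated at 200000 nM, most likely again reported as a limit, within 100000 nM to 1000000 nM.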

Compound 4, half-maximal cytotoxic concentration: > 100000 nM
Compound 4 was reported as a limit; the forecaster's own chance of this, stated with the estimate: 90%; the middle value does not contradict the limit.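

Compound 3 and compound 4 both stand at the limit in this assay, so no step can be read for this pair: the limit of > 100000 nM in this assay, at which 4 of the 4 values shown sit.

The compounds shown leave open at what concentration any of them becomes cytotoxic, and whether hydroxy(sulfo)methyl in place of formyl shifts that concentration.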